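Swapping a methoxyethyl chain for a cyanophenyl ring

The source may hold more compounds than are shown below. What is called first, only, known or untested is meant among the compounds shown, and "the series" means these compounds.

Measured so far:
- Compound 1, `CCc1cc(C)nn1-c1nc(C(F)(F)F)cc(=O)[nH]1`: 200000 nM
- Compound 2, `Cc1cc(NCCN(C)C)n(-c2nc(C(F)(F)F)cc(=O)[nH]2)n1`: 200000 nM
- Compound 3, `COCCNc1cc(C)nn1-c1nc(C(F)(F)F)cc(=O)[nH]1`: 200000 nM

All three share one core and differ only in the group attached to it. In a physicochemical assay for solubility, at pH 7.4 (a lower number here means a less soluble compound, a higher number a more soluble compound), compound 3 gives 200000 nM, level with compounds 1 and 2 at the digits shown. The step of no change at the digits printed from compound 1 to compound 3 (within the scatter) and the step of no change at the digits printed from compound 2 to compound 3 (within the scatter) both fall within the scatter, as does no change at the digits printed from compound 1 to compound 2 (within the scatter).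

Compound 4, `Cc1cc(Nc2ccc(C#N)cc2)n(-c2nc(C(F)(F)F)cc(=O)[nH]2)n1`, carries the change (4-cyanophenyl in place of 2-methoxyethyl on a nitrogen on an aromatic ring). Among the measured compounds shown here, none of the measured steps brings an aromatic ring into this position; each exchanged one open chain for another, and each left this assay unchanged. The measured steps therefore bear only loosely on the new change, and they give no sign of a rise. A modest fall is expected, a 3.3-fold lower number from compound 3 to compound 4 (0.52 log units; beyond the scatter), with wide uncertainty. For compound 4 the estimate in this assay is 60000 nM, expected to lie between 10000 nM and 200000 nM.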

Compound 4, solubility: 75000 nM
The estimate for compound 4 lay 1.3-fold (0.10 log units) below the measured number; the measured number falls inside the stated range.
By their numbers in this assay, from the lowest: compound 4; then compounds 1, 2 and 3 (each within the scatter of the next).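

In this assay the 4-cyanophenyl group is the only group shown on this nitrogen that moves the number beyond the scatter, with a 2.7-fold lower number from compound 3 to compound 4 (0.43 log units; beyond the scatter) and a 2.7-fold lower number from compound 2 to compound 4 (0.43 log units; beyond the scatter). The open chains on this nitrogen gave no such separation, so a modest drop appears only where an aromatic ring carrying a nitrile replaces a chain, even though 2-methoxyethyl and 4-cyanophenyl have the same counts of hydrogen-bond donors and acceptors. No supporting measurement is available to explain this drop.

The compounds shown cannot separate the contribution of the ring from that of its nitrile, a question that a plain phenyl group on this nitrogen would address. They also leave open how a saturated cyclohexyl ring, or a phenyl ring carrying a carboxylic acid instead of the nitrile, would compare.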